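Microsomal stability: chloro to fluoro on the anilino ring

This account rests on a few compounds, and the source may have more. Where it says the series, first, only, none or still open, it means among the compounds named here.

Two compounds of the series carry numbers in an ADME assay on microsomes from liver (Mus musculus) for metabolic stability, read by LC-MS; a higher number here means that the liver removes a larger share of the compound in one pass, a lower number that the liver removes a smaller share. Compound 1 `NCC(=O)N1CCn2c(nc(-c3cccc(F)c3)c2Nc2ccc(F)cc2)C1` gives 0.31. Compound 2 `NCC(=O)N1CCn2c(nc(-c3ccc(F)cc3)c2Nc2ccc(Cl)cc2)C1` gives 0.17 in this assay, the lowest of the two numbers, with compound 1 standing higher by a gap beyond the scatter. Compound 1 and compound 2 differ in two places, so no single step is shown between them.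

Compound 3 `NCC(=O)N1CCn2c(nc(-c3ccc(F)cc3)c2Nc2ccc(F)cc2)C1` is not yet measured. It differs from compound 2 in one place: fluoro in place of chloro on an aromatic carbon. Among the compounds with values here, no measured pair shows this change on its own in this assay; compound 1, which also carries a fluorine on that ring, differs elsewhere as well, so its higher number cannot be set against compound 2 directly.

For compound 3 a small rise in this assay is expected, of about a number 0.070 higher from compound 2 to compound 3 (within the scatter), a step close to the usual scatter. The estimate for compound 3 is 0.24, within 0.12 to 0.38.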

Compound 3, hepatic extraction ratio: 0.47
For compound 3 the middle estimate is 0.23 below the measured one, outside the stated range (above it).
By their numbers in this assay, from the lowest: compound 2; then compound 1; then compound 3.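

In this assay the change from (4-chlorophenyl)amino to (4-fluorophenyl)amino can now be read on its own: it gives a number 0.30 higher from compound 2 to compound 3 (beyond the scatter), so a single halogen exchange at this position moves the number beyond the scatter. The earlier pair could not separate this position from the other fluorine-bearing ring, but 4-fluorophenyl in place of 3-fluorophenyl now gives a number 0.16 higher from compound 1 to compound 3 (beyond the scatter), so a change at that ring also registers on its own. The data at hand offer no explanation for either step.

Going by these compounds, whether the chloro to fluoro step holds with 3-fluorophenyl on the other ring remains open. Also open, on these data alone, is where a methoxy group or a nitrile in place of the halogen would fall relative to compound 2 and compound 3.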